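Adding a chlorinated ring to compound 2

The compounds below may be only part of what the source reports. "The series", "measured", "known", "first", "only" and "open" are said of these compounds alone.

In a toxicity assay on THP-1 cells (Homo sapiens) for cytotoxicity (on this read-out higher numbers stand for an effect only at larger amounts of compound and lower numbers for an effect already at smaller amounts), compound 2 `CNc1ccnc2c(O)c(-c3nc(C)n[nH]3)ncc12` gives > 50100 nM, which is a limit and not a number. Its parent, compound 1 `Cc1n[nH]c(-c2ncc3cccnc3c2O)n1`, gives > 50100 nM, also a limit. Its methylated relative, compound 3 `Cc1n[nH]c(-c2ncc3c(N(C)C)ccnc3c2O)n1`, gives > 50100 nM, again a limit. The record so far is therefore (the limit of > 50100 nM in this assay, at which 3 of the 3 values shown sit).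

Compound 4 `Cc1n[nH]c(-c2ncc3c(NCc4ccc(Cl)cc4)ccnc3c2O)n1` differs from compound 2 by 4-chlorophenyl in place of hydrogen on a saturated chain carbon bound to a nitrogen on an aromatic ring, so that methyl becomes 4-chlorobenzyl. Two measured changes bear on this one. Adding methylamino gave a step that the two limits leave unreadable from compound 1 to compound 2, and adding a methyl on the nitrogen gave a step that the two limits leave unreadable from compound 2 to compound 3. Adding dimethylamino gave a step that the two limits leave unreadable from compound 1 to compound 3. None of these has a readable size, so they offer only weak guidance, and the new group is much larger than any of those groups.

A modest shift towards an effect at smaller amounts is expected, though the result may well remain at the limit. The expected change is an at least 1.6-fold lower number from compound 2 to compound 4 (0.22 log units; that floor lies within the scatter). For compound 4 the estimated value is 30000 nM, with an expected range from 8000 nM to 50100 nM.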

Compound 4, half-maximal effective concentration: > 50100 nM
Compound 4: only a limit was reported (the forecaster's own chance of this, stated with the estimate: 55%); middle value at least 1.6-fold (0.22 log units) away from the limit.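

The step from compound 2 to compound 4 cannot be read, since both compounds give a limit and not a number in this assay: the limit of > 50100 nM in this assay, at which 4 of the 4 values shown sit. The compounds shown leave open at what amount, if any, each of them would affect these cells.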